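Replacing the 2-(hydroxycarbamoyl)ethenyl group of compound 1

This account rests on a few compounds, and the source may have more. Where it says the series, first, only, none or still open, it means among the compounds named here.

In a functional assay on SW-620 cells (Homo sapiens) for cytotoxicity, read by colorimetric assay (on this read-out lower numbers stand for stronger inhibition and higher numbers for weaker inhibition), compound 1 `COc1ccc2c(c1)/C(=C1/Nc3ccccc3/C1=N\O)C(=O)N2Cc1ccc(/C=C/C(=O)NO)cc1` gives 40 nM and compound 2 `O=C(/C=C/c1ccc(CN2C(=O)/C(=C3\Nc4ccccc4\C3=N/O)c3cc(F)ccc32)cc1)NO` gives 50 nM. For the measured compounds named here, these are the only two numbers, and they lie within the scatter of each other, so compound 1 stands level with its single neighbour.

Compound 3 `COc1ccc2c(c1)/C(=C1/Nc3ccccc3/C1=N\O)C(=O)N2Cc1ccc(C(=O)NO)cc1` carries one change from compound 1, (hydroxycarbamoyl in place of 2-(hydroxycarbamoyl)ethenyl on an aromatic carbon), with hydroxycarbamoyl in place of 2-(hydroxycarbamoyl)ethenyl on an aromatic carbon. Going by the values given here, the only measured step, a 1.3-fold higher number from compound 1 to compound 2 (0.10 log units; within the scatter), is fluoro in place of methoxy elsewhere in the molecule, so it offers no direct guide to this change. Among the compounds with values here, with no measured step at this place, a modest move toward weaker inhibition in this assay is assumed, with wide margins. An estimated 2.8-fold higher number from compound 1 to compound 3 (0.44 log units; beyond the scatter) is expected. For compound 3 the expected value is 110 nM, with an estimated range of 35 nM to 400 nM.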

Compound 3, half-maximal inhibitory concentration: 40 nM
For compound 3 the middle estimate is 2.8-fold (0.44 log units) above the measured one; measured number inside the range.
By their numbers in this assay, from the lowest: compounds 1, 3 and 2 (each within the scatter of the next).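

In this assay, hydroxycarbamoyl in place of 2-(hydroxycarbamoyl)ethenyl gives no change at the digits printed from compound 1 to compound 3 (within the scatter) on this aromatic carbon, para to a large group. For the compounds shown here, this is the first reading at this position, since the earlier step concerned the fluoro and methoxy exchange elsewhere in the molecule, and it shows that on the core of compound 1 this read-out does not separate the two groups.

Open, from the compounds shown here alone, is whether a carboxylic acid or a primary amide on the same aromatic carbon would also keep the read-out level with compound 1, and whether a longer chain ending in hydroxycarbamoyl would do so. Also open, going by these compounds, is whether the same exchange reads alike on the fluoro core of compound 2. No measurement shown here bears on why the two groups read alike.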